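A few compounds are considered here, and "the series" means these few. Any claim that something is new, unique, unknown or untested is made for them only; others in the source may bear on it.

In an assay on isolated protein for displacement of a labelled ligand from melanin-concentrating hormone receptor 1 (Homo sapiens) (on this read-out higher numbers stand for weaker inhibition and lower numbers for stronger inhibition), compound 1 `O=C(CCc1ccc(C(F)(F)F)cc1)Nc1ccc2nc(N3CC4CCC3C4)ccc2c1` gives 1 nM, compound 2 `O=C(CCc1ccc(C(F)(F)F)cc1)Nc1ccc2nc(N3CC4CC3CN4)ccc2c1` gives 210 nM, and compound 3 `O=C(CCc1ccc(C(F)(F)F)cc1)Nc1ccc2nc(N3CC4CCC3CC4)ccc2c1` gives 3 nM. Compound 3 therefore holds the second highest number of the three: the step of a 3.0-fold higher number from compound 1 to compound 3 (0.48 log units; beyond the scatter) is modest, whereas a 70-fold lower number from compound 2 to compound 3 (1.85 log units; beyond the scatter) is large. Compound 4 `O=C(CCc1ccc(C(F)(F)F)cc1)Nc1ccc2nc(N3CCC4(CCNC4)C3)ccc2c1` differs from compound 3 at a single place: a group of 9 heavy atoms (7 carbon, 2 nitrogen; 2 five-membered non-aromatic rings with 1 hetero atom each) in place of a group of 8 heavy atoms (7 carbon, 1 nitrogen; 2 six-membered non-aromatic rings with 1 hetero atom each), on an aromatic carbon. The entering group resembles the group of compound 2 in that it brings two five-membered non-aromatic rings, a second nitrogen and one hydrogen-bond donor, whereas the group it replaces has none. Among the compounds with values here, two measured steps bear on this: a 210-fold higher number from compound 1 to compound 2 (2.32 log units; beyond the scatter) shows a large rise in the number when a donor-bearing, two-nitrogen bicycle enters, and a 70-fold lower number from compound 2 to compound 3 (1.85 log units; beyond the scatter) shows a large fall when it leaves again. A large upward step in this assay is therefore expected, giving a 100-fold higher number from compound 3 to compound 4 (2.00 log units; beyond the scatter). Compound 4 is estimated at 300 nM, with a likely range from 60 nM to 1500 nM.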

Compound 4, half-maximal inhibitory concentration: 0.5 nM
Beside the measured number, compound 4's estimate is 600-fold (2.78 log units) above it; the whole stated range lies above it.
By their numbers in this assay, from the lowest: compounds 4 and 1 (each within the scatter of the next); then compound 3; then compound 2.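

In this assay, a second nitrogen with a hydrogen-bond donor does not by itself spoil a group on this aromatic carbon next to the ring nitrogen, since the change brings a 6.0-fold lower number from compound 3 to compound 4 (0.78 log units; beyond the scatter) rather than a rise. Compound 2 and compound 4 both carry such a group with two five-membered non-aromatic rings, yet they show a 420-fold lower number from compound 2 to compound 4 (2.62 log units; beyond the scatter), so counting nitrogens and rings does not predict the number: the particular group matters. The second nitrogen also leaves compound 4 inseparable from compound 1, with a 2.0-fold lower number from compound 1 to compound 4 (0.30 log units; within the scatter) as the step.

Going by these compounds, how a methyl group on that second nitrogen, or an oxygen in its place, would read stays open. Nothing available explains why the groups of compound 2 and compound 4 give such different numbers.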